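The source may hold more compounds than are shown below. What is called first, only, known or untested is meant among the compounds shown, and "the series" means these compounds.

Of the compounds shown here, three sharing one core have been measured. Compound 1 `Cc1c(C(=O)Nc2ccc(Oc3ccnc4[nH]ccc34)cc2)nnn1-c1ccc(F)cc1` gives 220 nM in a functional assay on A549 cells (Homo sapiens) for cytotoxicity, read by MTT assay, with a stated time of 72 h; on this read-out lower numbers stand for stronger inhibition and higher numbers for weaker inhibition. Compound 2 `Cc1c(C(=O)Nc2ccc(Oc3ccnc4[nH]ccc34)cc2)nnn1-c1ccc(Cl)c(C(F)(F)F)c1` gives 2830 nM in this assay, and compound 3 `O=C(Nc1ccc(Oc2ccnc3[nH]ccc23)cc1)c1nnn(-c2ccc(F)cc2)c1C(F)(F)F` gives 180 nM in this assay. The step of a 1.2-fold lower number from compound 1 to compound 3 (0.09 log units; within the scatter) is small, so compound 3 has the lowest number of the three only nominally, with compound 1 within the scatter and compound 2 well beyond it.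

Compound 4 `O=C(Nc1ccc(Oc2ccnc3[nH]ccc23)cc1)c1nnn(-c2ccc(Cl)c(C(F)(F)F)c2)c1C(F)(F)F` differs from compound 3 by 4-chloro-3-(trifluoromethyl)phenyl in place of 4-fluorophenyl on an aromatic nitrogen. The same exchange on an aromatic nitrogen has been seen once, as a 13-fold higher number from compound 1 to compound 2 (1.11 log units; beyond the scatter), a large loss. In this assay the expected step is therefore a 13-fold higher number from compound 3 to compound 4 (1.11 log units; beyond the scatter), towards a higher number. Compound 4 is estimated at 2300 nM, with a range from 800 nM to 7000 nM.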

Compound 4, half-maximal inhibitory concentration: 2340 nM
Compound 4: middle estimate off by 1.0-fold (0.01 log units), on the low side, and the stated range covers the measured number.
By their numbers in this assay, from the lowest: compounds 3 and 1 (each within the scatter of the next); then compounds 4 and 2 (each within the scatter of the next).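

In this assay, the exchange of 4-fluorophenyl for 4-chloro-3-(trifluoromethyl)phenyl on the aromatic nitrogen gives a 13-fold higher number from compound 3 to compound 4 (1.11 log units; beyond the scatter), so the large loss appears with trifluoromethyl as well as with methyl on the aromatic carbon: the same change on two cores in this assay, a 13-fold higher number (1.11 log units; beyond the scatter) from compound 1 to compound 2 and a 13-fold higher number (1.11 log units; beyond the scatter) from compound 3 to compound 4, 1.0-fold (0.00 log units) apart, within the scatter of two such steps The exchange of methyl for trifluoromethyl on that carbon also remains small with the larger aryl group, at a 1.2-fold lower number from compound 2 to compound 4 (0.08 log units; within the scatter): the same change on two cores in this assay, a 1.2-fold lower number (0.09 log units; within the scatter) from compound 1 to compound 3 and a 1.2-fold lower number (0.08 log units; within the scatter) from compound 2 to compound 4, 1.0-fold (0.00 log units) apart, within the scatter of two such steps The compounds shown leave open how chlorine alone or trifluoromethyl alone on the phenyl ring would read, and how an amine or a carboxylic acid there would compare.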